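From dimethylcarbamoyl to 3,3-dimethylbutyl in compound 4

The compounds below may be only part of what the source reports. "The series", "measured", "known", "first", "only" and "open" are said of these compounds alone.

compound 1 `O=C1CC[C@@H](C(=O)N2CCC(NS(=O)(=O)c3cc(S(=O)(=O)c4ccccc4)ccc3C(F)(F)F)CC2)N1`: 100000 nM
compound 2 `CN(C)c1ccc(C(=O)N2CCC[C@H]2C(=O)N2CCC(NS(=O)(=O)c3cc(S(=O)(=O)c4ccccc4)ccc3C(F)(F)F)CC2)cc1`: 100000 nM
compound 3 `CN(C)C(=O)N1CCC[C@H]1C(=O)N1CCC(NS(=O)(=O)c2cc(S(=O)(=O)c3ccccc3)ccc2C(F)(F)F)CC1`: 100000 nM

All three values come from a physicochemical assay for solubility (a higher number here means a more soluble compound, a lower number a less soluble compound), and they are identical, so compound 3 stands level with compound 1 and compound 2. Compound 4 `CC(C)(C)CCN1CCC[C@H]1C(=O)N1CCC(NS(=O)(=O)c2cc(S(=O)(=O)c3ccccc3)ccc2C(F)(F)F)CC1` keeps the rest of compound 3 and alters one group (3,3-dimethylbutyl in place of dimethylcarbamoyl on an amine nitrogen in a ring): 3,3-dimethylbutyl in place of dimethylcarbamoyl on an amine nitrogen in a ring.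

Going by the values given here, two measured steps bear on this change, and each exchanged a group on a carbonyl carbon: no change at the digits printed from compound 1 to compound 3 (within the scatter) and no change at the digits printed from compound 2 to compound 3 (within the scatter). Neither moved the number beyond the scatter. Among the compounds with values here, no measured compound carries 3,3-dimethylbutyl, however, so these steps are only a loose guide. The expected outcome is no shift beyond the scatter (a 1.3-fold lower number from compound 3 to compound 4 (0.10 log units; within the scatter)). Compound 4 is estimated at 80000 nM in this assay, with a wide expected range (30000 nM to 100000 nM).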

Compound 4, solubility: 12500 nM
Beside the measured number, compound 4's estimate is 6.4-fold (0.81 log units) above it; the whole stated range lies above it.
By their numbers in this assay, from the lowest: compound 4; then compounds 1, 2 and 3 (each within the scatter of the next).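

In this assay, going by these compounds alone, earlier changes on a carbonyl carbon left the number unmoved, but this change on the amine nitrogen in the ring gives the first step beyond the scatter, an 8.0-fold lower number from compound 3 to compound 4 (0.90 log units; beyond the scatter) for 3,3-dimethylbutyl in place of dimethylcarbamoyl. The comparisons with the other two compounds match it, with an 8.0-fold lower number from compound 2 to compound 4 (0.90 log units; beyond the scatter) and an 8.0-fold lower number from compound 1 to compound 4 (0.90 log units; beyond the scatter) on their own lines of comparison, so this nitrogen's substituent can alter the read-out. Nothing measured here explains the drop.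

The all-carbon 3,3-dimethylbutyl chain has no hydrogen-bond acceptor and the dimethylcarbamoyl group has one, but whether that difference or the chain itself matters remains unsettled. A shorter chain such as ethyl, or a chain ending in an amine or a carboxylic acid, could help separate the two.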